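Nitro in Place of Hydrogen: Expected Effect on Compound 4

The compounds below may be only part of what the source reports. "The series", "measured", "known", "first", "only" and "open" are said of these compounds alone.

Compound 1 `CC1=C(/C=C/C(=O)/C=C/c2ccccc2)C(C)(C)CCC1`: 20400 nM
Compound 2 `CC1=C(/C=C/C(=O)/C=C/c2ccc(C#N)cc2)C(C)(C)CCC1`: 23400 nM
Compound 3 `CC1=C(/C=C/C(=O)/C=C/c2ccc(C)cc2)C(C)(C)CCC1`: 19200 nM

Among the three compounds measured in a functional assay on IMR-32 cells (Homo sapiens) for cytotoxicity, read by sulforhodamine B assay, with a stated time of 48 h (a lower number here means a stronger inhibitor, a higher number a weaker inhibitor), compound 1 gives the second highest number, and both steps away from it, a 1.1-fold higher number from compound 1 to compound 2 (0.06 log units; within the scatter) and a 1.1-fold lower number from compound 1 to compound 3 (0.03 log units; within the scatter), lie within the scatter, as does a 1.2-fold lower number from compound 2 to compound 3 (0.09 log units; within the scatter). Compound 4 `CC1=C(/C=C/C(=O)/C=C/c2ccccc2[N+](=O)[O-])C(C)(C)CCC1` differs from compound 1 by nitro in place of hydrogen on an aromatic carbon. Among the compounds with values here, the only measured steps that bear on this change are the two replacements of a hydrogen on an aromatic carbon, a 1.1-fold higher number from compound 1 to compound 2 (0.06 log units; within the scatter) and a 1.1-fold lower number from compound 1 to compound 3 (0.03 log units; within the scatter), neither of which moved the number beyond the scatter; no measured step involves a nitro group or a group ortho to a large group. Compound 4 is therefore expected to show no step beyond the scatter, a 1.0-fold lower number from compound 1 to compound 4 (0.01 log units; within the scatter). The estimate for compound 4 is 20000 nM, with a range from 8000 nM to 50000 nM.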

Compound 4, half-maximal inhibitory concentration: 13500 nM
Estimate against measurement, compound 4: 1.5-fold (0.17 log units) above; low and high end bracket the measured number.
By their numbers in this assay, from the lowest: compounds 4, 3, 1 and 2 (each within the scatter of the next).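

In this assay, nitro in place of hydrogen on an aromatic carbon, ortho to a large group, gives a 1.5-fold lower number from compound 1 to compound 4 (0.18 log units; within the scatter). The aromatic ring of the core of compound 1 therefore accepts a nitro group at this position without a step beyond the scatter, which the earlier cyano and methyl replacements could not show. Nothing available explains the size of this step.

The compounds shown leave open whether an amine or a carboxylic acid at this position would move the number beyond the scatter. They also leave open how nitro would behave on another carbon of the same ring.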